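Sulfonyl-quinolone series: changing the aryl group on the sulfonyl

This account rests on a few compounds, and the source may have more. Where it says the series, first, only, none or still open, it means among the compounds named here.

Compound 1 `COc1ccc(-c2c(Cl)c(=O)c3c(OC)cc(OC)cc3n2S(=O)(=O)c2ccc(OC)cc2)cc1`: "not determined" (no result reported)
Compound 2 `COC(=O)c1cc(=O)c2c(OC)cc(OC)cc2n1S(=O)(=O)c1ccc(C)cc1`: > 20000 nM
Compound 3 `COc1ccc(-c2cc(=O)c3c(OC)cc(OC)cc3n2S(=O)(=O)c2ccc(C=O)cc2)cc1`: > 34400 nM

In a functional assay on HepG2 cells (Homo sapiens) for antiproliferative activity, with a stated time of 72 h (a lower number here means that less compound is needed, a higher number that more compound is needed for the effect), compound 3 gives > 34400 nM, which is a limit of the assay and not a number. Compound 2 in this assay likewise gives only a limit, > 20000 nM. For compound 1 in this assay no result is reported: "not determined" (no result reported). Compound 3 therefore stands at a limit, and the whole set offers nothing beyond the two limits the limit of > 20000 nM in this assay, at which 1 of the 3 values shown sits, and the limit of > 34400 nM in this assay, at which 1 of the 3 values shown sits, to compare it with. Compound 4 `COc1ccc(-c2cc(=O)c3c(OC)cc(OC)cc3n2S(=O)(=O)c2cccc(Br)c2)cc1` differs from compound 3 by 3-bromophenyl in place of 4-formylphenyl on a sulfonyl sulfur. Among the measured compounds shown here, no step between measured compounds is available, so no direction can be read from the numbers; the expected step of an at least 1.1-fold lower number from compound 3 to compound 4 (0.05 log units; that floor lies within the scatter) is none beyond the scatter. Compound 4 is estimated at 30000 nM, within a range from 5000 nM to 100000 nM, and is expected most likely to return only a limit again.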

Compound 4, half-maximal effective concentration: > 58600 nM
Compound 4 ended at the assay's limit; the forecaster's own chance of this, stated with the estimate: 65%; middle value at least 1.9-fold (0.29 log units) away from the limit.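

Among the compounds shown here, compound 3 and compound 4 both end at limits of the assay, so no step between them can be read. The compounds shown leave open whether any aryl group on the sulfonyl gives a real number in this assay.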